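A few compounds are considered here, and "the series" means these few. Any claim that something is new, unique, unknown or untested is made for them only; others in the source may bear on it.

Measured so far in an assay on HEK293 cells for inhibition of Voltage-dependent T-type calcium channel subunit alpha-1G (Homo sapiens), read by patch clamp; on this read-out lower numbers stand for stronger inhibition and higher numbers for weaker inhibition:

- compound 1 `CCCc1nc(-c2ccccc2)c(CNCCN2CCN(c3ccc(Cl)cc3)CC2)o1`: 2820 nM
- compound 2 `CCCc1nc(-c2ccccc2)c(CNCCN2CCN(c3cccc(F)c3)CC2)o1`: 3350 nM

Among the compounds with values here, compound 2 and compound 1 are the only two compounds with numbers in this assay, and the one step between them, a 1.2-fold higher number from compound 1 to compound 2 (0.07 log units; within the scatter), is within the scatter. Compound 2 therefore stands at one end of a pair whose two values cannot be told apart; nothing here separates it from compound 1.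

Compound 3 `CCCc1nc(-c2ccccc2)c(CNCCN2CCN(c3cccc(Cl)c3)CC2)o1` differs from compound 2 by chloro in place of fluoro on an aromatic carbon. Within the data shown here, the only measured step that touches this part of the molecule is the one from compound 1 to compound 2, which exchanged both the halogen and its position on the phenyl at the same time and stayed within the scatter. Among the measured compounds shown here, no measured step isolates a fluoro-to-chloro swap at a fixed position. With that single, flat precedent, no step beyond the scatter is expected in this assay for compound 3 relative to compound 2; the expected step is a 1.1-fold lower number from compound 2 to compound 3 (0.05 log units; within the scatter). Compound 3 is accordingly estimated at 3000 nM, with a range from 1200 nM to 7500 nM.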

Compound 3, half-maximal inhibitory concentration: 1450 nM
Estimate against measurement, compound 3: 2.1-fold (0.32 log units) above, and the stated range covers the measured number.
By their numbers in this assay, from the lowest: compounds 3, 1 and 2 (each within the scatter of the next, the first and the last beyond it).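

In this assay, within the data shown here, chloro in place of fluoro on an aromatic carbon, meta to a large group, gives a 2.3-fold lower number from compound 2 to compound 3 (0.36 log units; beyond the scatter) as the first change confined to a single atom at a fixed place, and this modest step is the only one so far to lie beyond the scatter. With chloro kept, 3-chlorophenyl in place of 4-chlorophenyl gives a 1.9-fold lower number from compound 1 to compound 3 (0.29 log units; within the scatter) and stays within the scatter, so these values do not resolve any preference between the two ring positions, while the identity of the halogen at the 3-position does register in this read-out. Nothing available explains why chloro and fluoro part here.

Whether the step continues beyond these two halogens remains open, since only chloro and fluoro are shown at this place, and bromo, methyl, methoxy or trifluoromethyl there, or a phenyl carrying no halogen at all, could extend or break it. As far as these compounds go, the step also rests on a single pair on one core, so its size with a different chain on that core, such as a longer chain in place of propyl, remains unknown.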